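From cyclohexylamino to propoxy on a shared core

A few compounds are considered here, and "the series" means these few. Any claim that something is new, unique, unknown or untested is made for them only; others in the source may bear on it.

Compound 1 `CNc1nc(N)nc2c1ncn2/C=C1/CC1(CO)CO` gives 67000 nM as a number
Compound 2 `Nc1nc(NC2CCCCC2)c2ncn(/C=C3/CC3(CO)CO)c2n1` gives > 20000 nM as a limit

In an ADME assay on BCBL1 cells (Homo sapiens) for cytotoxicity, with a stated time of 7 days (on this read-out higher numbers stand for lower toxicity in this test and lower numbers for higher toxicity in this test), compound 2 stands at > 20000 nM and this is a limit of the assay, not a number. Among the compounds with values here, the only true number so far comes from compound 1 with 67000 nM on the same read-out. Within the data shown here, the one measured step that bears on the change is a step that the limit leaves unreadable from compound 1 to compound 2 and it offers no size to carry forward.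

Compound 3 `CCCOc1nc(N)nc2c1ncn2/C=C1/CC1(CO)CO` differs from compound 2 as follows: propoxy in place of cyclohexylamino on an aromatic carbon in words, propoxy in place of cyclohexylamino on an aromatic carbon. With no readable step to lean on, no direction can be expected in this assay and no change beyond the scatter is predicted. The expected move is a step that the limit leaves unreadable from compound 2 to compound 3 and this remains only an estimate. The estimated value for compound 3 is 30000 nM with an expected range from 8000 nM to 90000 nM in this test.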

Compound 3, half-maximal cytotoxic concentration: > 20000 nM
Compound 3: only a limit was reported; the forecaster's own chance of this, stated with the estimate: 45%; the middle value lies beyond the limit too.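

In this assay compound 3 gives > 20000 nM, which is a limit and not a number. No step between compound 1, compound 2 and compound 3 can be read, because the comparison runs into a limit: the limit of > 20000 nM in this assay, at which 2 of the 3 values shown sit.

Where compound 2 and compound 3 truly stand, relative to each other and to compound 1, stays open.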